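Methyl to methoxy on the five-membered ring: compound 4

The compounds below may be only part of what the source reports. "The series", "measured", "known", "first", "only" and "open" are said of these compounds alone.

Measured compounds:
compound 1 `CCc1nc(C(C)C)c2n1CCN([C@@H](C(=O)NC)c1ccccc1)C2CCc1ccc(C(F)(F)F)cc1`: 2900 nM
compound 2 `CNC(=O)[C@@H](c1ccccc1)N1CCn2c(CC3CC3)nc(Cl)c2[C@@H]1CCc1ccc(C(F)(F)F)cc1`: 35 nM
compound 3 `CCc1nc(C)c2n1CCN([C@@H](C(=O)NC)c1ccccc1)C2CCc1ccc(C(F)(F)F)cc1`: 24 nM

All numbers come from a functional assay on CHO cells for antagonist activity at Orexin receptor type 2 (Homo sapiens), read by FLIPR and calcium flux; on this read-out higher numbers stand for weaker inhibition and lower numbers for stronger inhibition. Among the measured compounds shown here, compound 3 gives the lowest of the three, but compound 2 lies within the scatter of it; only compound 1 stands clearly apart, through the one measured single change at this ring carbon, a 120-fold lower number from compound 1 to compound 3 (2.08 log units; beyond the scatter). Compound 4 `CCc1nc(OC)c2n1CCN([C@@H](C(=O)NC)c1ccccc1)C2CCc1ccc(C(F)(F)F)cc1` differs from compound 3 by methoxy in place of methyl on an aromatic carbon. That measured step shows a much higher number with isopropyl than with methyl, while the chloro-bearing compound 2 and compound 3 give close numbers. Nothing measured separates methoxy from methyl here, so no step beyond the scatter is expected. Compound 4 is estimated at 40 nM, range 12 nM to 150 nM. This amounts to an expected step of a 1.7-fold higher number from compound 3 to compound 4 (0.22 log units; within the scatter).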

Compound 4, half-maximal inhibitory concentration: 73 nM
Compound 4: the middle estimate sits 1.8-fold (0.26 log units) below what was measured; the measured number falls inside the stated range.
By their numbers in this assay, from the lowest: compounds 3 and 2 (each within the scatter of the next); then compound 4; then compound 1.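

At this ring carbon even a small exchange registers in this assay: methoxy in place of methyl gives a 3.0-fold higher number from compound 3 to compound 4 (0.48 log units; beyond the scatter) and so lies beyond the scatter, so sensitivity here is not limited to isopropyl. Methoxy nevertheless stands far from isopropyl, with a 40-fold lower number from compound 1 to compound 4 (1.60 log units; beyond the scatter) on that exchange. Nothing measured on these compounds accounts for either step. Still open, going by these compounds, is whether an amine or an ethoxy group at this carbon would track methyl or methoxy, and whether the order of methyl, methoxy and isopropyl holds with a longer chain replacing the ethyl group.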